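A Measurement Awaited: Compound 4 Against Hexokinase-1

The compounds below may be only part of what the source reports. "The series", "measured", "known", "first", "only" and "open" are said of these compounds alone.

Compound 2 `O=C(CI)NCCNc1ncnc2c1ncn2[C@@H]1O[C@H](COP(=O)(O)OP(=O)(O)OP(=O)(O)O)[C@@H](O)[C@H]1O` was tested in an assay on isolated protein for inhibition of hexokinase-1 (Rattus norvegicus), with a stated time of 6 h, tested at 10 mM (a higher number here means more inhibition at the concentration tested (going by the name of the read-out), a lower number less inhibition), and gives 0%. Compound 1 `O=C(CI)NCCCCNc1ncnc2c1ncn2[C@@H]1O[C@H](COP(=O)(O)OP(=O)(O)OP(=O)(O)O)[C@@H](O)[C@H]1O` gives 0% in this assay, and compound 3 `CN(CCCCN(C)C(=O)CCCCNc1ncnc2c1ncn2[C@@H]1O[C@H](COP(=O)(O)OP(=O)(O)OP(=O)(O)O)[C@@H](O)[C@H]1O)C(=O)CCCCNC(=O)CI` gives 0%. Among the compounds with values here, compound 2 therefore stands level with both companions at the digits reported, and no measured compound shows any inhibition at the concentration used. Within the data shown here, the only single-point step measured so far, no change at the digits printed from compound 1 to compound 2 (within the scatter), shows no change within the scatter.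

Compound 4 `CC(=O)NCCCCCCCCNc1ncnc2c1ncn2[C@@H]1O[C@H](COP(=O)(O)OP(=O)(O)OP(=O)(O)O)[C@@H](O)[C@H]1O` has not yet been measured. It differs from compound 2 in one place: 6-acetamidohexyl in place of ((iodomethyl)carbonyl)amino on a saturated chain carbon, two bonds along the chain from a nitrogen on an aromatic ring. Among the measured compounds shown here, no measured step covers this exchange. What the data do show is that the step from compound 1 to compound 2 left the read-out unchanged and that all three measured compounds sit at the bottom of the scale. Nothing here points toward inhibition appearing, so the expected step of no change at the digits printed from compound 2 to compound 4 (within the scatter) is none beyond the scatter. Compound 4 is estimated to give 0% in this assay, within a range from 0% to 12%.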

Compound 4, a percentage reported as inhibition, at one concentration (the size of the read-out at that concentration, not a potency): 0%
The estimate for compound 4 equals the measured number at the digits printed, and the stated range covers the measured number.
By their numbers in this assay, from the lowest: compounds 1, 2, 3 and 4 (each within the scatter of the next).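

In this assay, putting 6-acetamidohexyl in place of ((iodomethyl)carbonyl)amino, on a saturated chain carbon two bonds along the chain from a nitrogen on an aromatic ring, gives no change at the digits printed from compound 2 to compound 4 (within the scatter) and so leaves the reading where it was. The same holds four bonds along the chain, where 4-acetamidobutyl replaces ((iodomethyl)carbonyl)amino and the result is no change at the digits printed from compound 1 to compound 4 (within the scatter) for a change that, unlike the earlier step, removes the iodine and keeps the acetamide-type end. All these compounds sit at the bottom of the scale, so these steps cannot show whether either group adds or takes away anything, and no measurement here offers an explanation.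

As far as these compounds go, whether an amine or a carboxylic acid in place of the acetamido group would give any inhibition remains open. A chain longer than 8-acetamidooctyl is equally untested by these compounds.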